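Selenocyanate carbamates: allyl to ethyl step

The source may report more compounds than this note shows. Statements on the series, on what has been measured and on what is new or still open speak of the compounds shown alone.

Working notes on the series. Compound 1 `N#C[Se]c1ccc(NC(=O)Oc2ccc(F)cc2)cc1` and compound 2 `C=CCOC(=O)Nc1ccc([Se]C#N)cc1` share the same core and differ only in the group on the carbamate oxygen. In a functional assay on HTB-54 cells (Homo sapiens) for cytotoxicity, read by MTT assay, with a stated time of 72 h (on this read-out lower numbers stand for stronger inhibition of growth and higher numbers for weaker inhibition of growth), compound 1 gives 48400 nM, and in this assay compound 2 gives 50100 nM. Compound 2 holds the highest of the two numbers in this assay, but its gap to compound 1 lies within the scatter, so the two compounds cannot be told apart on these figures. Compound 3 `CCOC(=O)Nc1ccc([Se]C#N)cc1` is the next member and has not yet been measured. Its change from compound 2 is methyl in place of vinyl on a saturated chain carbon bound to an oxygen next to a carbonyl group. Going by the values given here, no step between measured compounds bears on this change, so the expectation rests on the two values shown, which sit close together. In this assay compound 3 is expected to give 50000 nM, with a range from 25000 nM to 100000 nM. The estimated step of a 1.0-fold lower number from compound 2 to compound 3 (0.00 log units; within the scatter) is expected to stay within the scatter, in no set direction.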

Compound 3, concentration for total growth inhibition: 49300 nM
Estimate against measurement, compound 3: 1.0-fold (0.01 log units) above, within the range that was stated.
By their numbers in this assay, from the lowest: compounds 1, 3 and 2 (each within the scatter of the next).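

In this assay, going by these compounds alone, allyl to ethyl gives a 1.0-fold lower number from compound 2 to compound 3 (0.01 log units; within the scatter) and is the first direct reading of a change on a saturated chain carbon bound to an oxygen next to a carbonyl group. Methyl in place of vinyl removes the one double bond outside aromatic rings, yet compound 2 and compound 3 cannot be told apart on these figures. The double bond of the allyl group is therefore not needed for a value of this size in this assay, though this rests on a single pair.

On these data alone, whether a longer chain such as butyl, or an amine or carboxylic acid at the end of the chain, would give a number beyond the scatter remains open. No measurement at hand offers an explanation for this result.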